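This account rests on a few compounds, and the source may have more. Where it says the series, first, only, none or still open, it means among the compounds named here.

Compound 1 `COc1ccc(-n2cc(NC(=O)c3cccc(NS(=O)(=O)c4ccccc4)c3)cn2)cc1` gives 18700 nM in a functional assay on MCF7 cells (Homo sapiens) for inhibition, read by MTT assay, with a stated time of 48 h; a higher number here means a weaker inhibitor, a lower number a stronger inhibitor. Compound 2 `COc1cccc(-n2cc(NC(=O)c3cccc(NS(=O)(=O)c4ccccc4)c3)cn2)c1` gives 16700 nM in this assay; the change between them is 3-methoxyphenyl in place of 4-methoxyphenyl on an aromatic nitrogen, and it made a 1.1-fold lower number from compound 1 to compound 2 (0.05 log units; within the scatter). Compound 3 `COc1ccc(-n2cc(NC(=O)c3cccc(NS(=O)(=O)c4ccc(Cl)cc4)c3)cn2)cc1` gives 8720 nM in this assay; it differs from compound 1 by chloro in place of hydrogen on an aromatic carbon, a change that made a 2.1-fold lower number from compound 1 to compound 3 (0.33 log units; beyond the scatter). Compound 4 `COc1cccc(-n2cc(NC(=O)c3cccc(NS(=O)(=O)c4ccc(Cl)cc4)c3)cn2)c1` is not yet measured. It differs from compound 3 by 3-methoxyphenyl in place of 4-methoxyphenyl on an aromatic nitrogen, the same change that turns compound 1 into compound 2, at the same place. Because that earlier change made a 1.1-fold lower number from compound 1 to compound 2 (0.05 log units; within the scatter), the expected step in this assay is similar, a 1.1-fold lower number from compound 3 to compound 4 (0.04 log units; within the scatter). The estimate for compound 4 in this assay is therefore 8000 nM, expected to fall between 4000 nM and 16000 nM.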

Compound 4, half-maximal inhibitory concentration: 9430 nM
For compound 4 the middle estimate is 1.2-fold (0.07 log units) below the measured one; the measured number falls inside the stated range.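

Exchanging 4-methoxyphenyl for 3-methoxyphenyl on the chloro-bearing core gives a 1.1-fold higher number from compound 3 to compound 4 (0.03 log units; within the scatter) in this assay, and this step matches the one seen without the chloro: the same change on two cores in this assay, a 1.1-fold lower number (0.05 log units; within the scatter) from compound 1 to compound 2 and a 1.1-fold higher number (0.03 log units; within the scatter) from compound 3 to compound 4, 1.2-fold (0.08 log units) apart, within the scatter of two such steps

The chloro change, now read on the 3-methoxyphenyl core, gives a 1.8-fold lower number from compound 2 to compound 4 (0.25 log units; within the scatter), and it also matches its earlier step: the same change on two cores in this assay, a 2.1-fold lower number (0.33 log units; beyond the scatter) from compound 1 to compound 3 and a 1.8-fold lower number (0.25 log units; within the scatter) from compound 2 to compound 4, 1.2-fold (0.08 log units) apart, within the scatter of two such steps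

So each change carried across these two cores with no gap beyond the scatter, but each comparison rests on one pair of steps, and this does not show that either step would hold on any other core.

On these data alone, whether a carboxylic acid or an amine in place of the chloro would give a larger step stays open. So does the effect of replacing the methoxy with a longer chain.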